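The source may hold more compounds than are shown below. What is called first, only, known or untested is meant among the compounds shown, and "the series" means these compounds.

Working notes on the diaryl urea series.

Compound 1 `O=C(Nc1ccccc1)Nc1ccc(Oc2ccc(-c3nccs3)cc2)cc1` carries an unsubstituted phenyl on the urea, and in a functional assay on MDA-MB-231 cells (Homo sapiens) for inhibition, read by MTT assay and WST assay, with a stated time of 72 h, tested at 10 uM (on this read-out higher numbers stand for more inhibition of growth at the one concentration tested and lower numbers for less inhibition of growth), compound 1 gives "not determined" (no result reported). Among the compounds with values here, compound 2 `O=C(Nc1ccc(Oc2ccc(-c3nccs3)cc2)cc1)Nc1ccc(F)c(C(F)(F)F)c1` is the only member with a number: in this assay compound 2 gives 71.8%, so it stands alone and serves as the sole reference point.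

Compound 3 `Cc1ccc(NC(=O)Nc2ccc(Oc3ccc(-c4nccs4)cc3)cc2)cc1` has not yet been measured. It differs from compound 2 in one place: 4-methylphenyl in place of 4-fluoro-3-(trifluoromethyl)phenyl on an amide-type nitrogen. Within the data shown here, no step between measured compounds exists for this or any related change, so the direction rests on the single reference value. The expectation is a step downward beyond the scatter, of about a number 26.8 percentage points lower from compound 2 to compound 3 (beyond the scatter). For compound 3 the estimate in this assay is 45%, with a range from 15% to 75%.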

Compound 3, percent growth inhibition at one concentration: 22.8%
Beside the measured number, compound 3's estimate is 22.2 percentage points above it; the range from low to high includes it.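

In this assay, within the data shown here, 4-methylphenyl in place of 4-fluoro-3-(trifluoromethyl)phenyl on an amide-type nitrogen gives a number 49 percentage points lower from compound 2 to compound 3 (beyond the scatter), the first step that can be read. With the rest of the structure unchanged, this position is sensitive: this one exchange of aromatic group moves growth inhibition at the single concentration tested by a large margin, well beyond the scatter. Nothing measured here accounts for the size of this step.

The change removes the fluoro and trifluoromethyl groups and introduces a methyl group in one move, so the compounds shown do not separate the contribution of each. Also open, as far as these compounds go, is how this position responds to a 4-fluorophenyl, a 3-(trifluoromethyl)phenyl, a 4-aminophenyl or a 4-carboxyphenyl group.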